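A ring exchange on compound 3

The source may hold more compounds than are shown below. What is called first, only, known or untested is meant among the compounds shown, and "the series" means these compounds.

Measured so far in a functional assay on HeLa cells (Homo sapiens) for cytotoxicity, read by MTT assay (on this read-out higher numbers stand for weaker inhibition and lower numbers for stronger inhibition), are these values
Compound 1 `CCCCC(O)CC(=O)O[C@H](CC=C(C)C)C1=CC(=O)c2c(O)ccc(O)c2C1=O` gives 72200 nM
Compound 2 `CCC(CO[C@H](CC=C(C)C)C1=CC(=O)c2c(O)ccc(O)c2C1=O)OC(C)=O` gives 44000 nM
Compound 3 `CC(C)=CC[C@@H](OC(=O)C1CCOC1)C1=CC(=O)c2c(O)ccc(O)c2C1=O` gives 73500 nM

On these numbers, compound 3 cannot be told apart from the other two. The data show a 1.0-fold higher number from compound 1 to compound 3 (0.01 log units; within the scatter) and also a 1.7-fold higher number from compound 2 to compound 3 (0.22 log units; within the scatter) as steps that stay inside the normal noise of the measurement.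

Compound 4 `CC(C)=CC[C@@H](OC(=O)C1CCCCO1)C1=CC(=O)c2c(O)ccc(O)c2C1=O` keeps the shared core and changes one group on a carbonyl carbon (oxan-2-yl in place of oxolan-3-yl on a carbonyl carbon). Within the data shown here, no measured compound carries oxan-2-yl, so the closest guide is the exchange on that same carbonyl carbon, a 1.0-fold higher number from compound 1 to compound 3 (0.01 log units; within the scatter) with oxolan-3-yl in place of 2-hydroxyhexyl. The wider exchange in a 1.6-fold lower number from compound 1 to compound 2 (0.22 log units; within the scatter) also gave no clear shift. So far, all three compounds have stayed together despite their different groups.

No change beyond the scatter is therefore expected in this assay and the estimated step is a 1.1-fold lower number from compound 3 to compound 4 (0.05 log units; within the scatter) in either direction.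

Compound 4 is estimated at 65000 nM (expected range 35000 nM to 115000 nM).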

Compound 4, half-maximal inhibitory concentration: > 100000 nM
Compound 4: no number, only a limit; the forecaster's own chance of this, stated with the estimate: 10%; middle value at least 1.5-fold (0.18 log units) from the limit.
By their numbers in this assay, from the lowest: compounds 2, 1 and 3 (each within the scatter of the next). At a limit, above all of these: compound 4.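

Compound 4 gives > 100000 nM in this assay, and this is a limit of the assay, not a number: the limit of > 100000 nM in this assay, at which 1 of the 4 values shown sits. Among these compounds, for the first time, this position on the carbonyl carbon separates two compounds, with an at least 2.2-fold higher number from compound 2 to compound 4 (0.35 log units; beyond the scatter), although that pair differs by the whole group on the oxygen rather than by the ring alone. The other two readings, an at least 1.3-fold higher number from compound 3 to compound 4 (0.13 log units; that floor lies within the scatter) and an at least 1.3-fold higher number from compound 1 to compound 4 (0.14 log units; that floor lies within the scatter), are only floors, so oxan-2-yl in place of oxolan-3-yl cannot yet be called a real loss, though the true step may be larger.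

The compounds shown leave open how far beyond the limit compound 4 lies. They also cannot separate ring size from the ring's point of attachment, a question that oxolan-2-yl and oxan-3-yl on the same carbonyl carbon would address.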